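The source may hold more compounds than are shown below. What is called first, only, known or untested is meant among the compounds shown, and "the series" means these compounds.

Measured compounds and their values in an ADME assay on HEK-293T cells (Homo sapiens) for inhibition, read by CCK-8 assay, with a stated time of 48 h, tested at 20 uM; on this read-out higher numbers stand for more inhibition of growth at the one concentration tested and lower numbers for less inhibition of growth:
compound 1 `COc1ccc(S(=O)(=O)Oc2ccccc2/C=C(\C#N)C(=O)Nc2nnc(Cc3cccc4ccccc34)s2)cc1`: 29%
compound 2 `N#C/C(=C\c1ccccc1OS(=O)(=O)c1ccc([N+](=O)[O-])cc1)C(=O)Nc1nnc(Cc2cccc3ccccc23)s1`: 25%
compound 3 `COc1ccc(S(=O)(=O)Oc2ccccc2/C=C(\C#N)C(=O)Nc2nnc(Cc3ccc(F)cc3)s2)cc1`: 20%

The three share one core and differ at two places. From compound 1 to compound 2 the change is nitro in place of methoxy on an aromatic carbon, and the step in this assay is a number 4 percentage points lower from compound 1 to compound 2 (within the scatter). From compound 1 to compound 3 the change is 4-fluorophenyl in place of naphthalen-1-yl on a saturated chain carbon bound to an aromatic carbon, giving a number 9 percentage points lower from compound 1 to compound 3 (within the scatter). Compound 4 `N#C/C(=C\c1ccccc1OS(=O)(=O)c1ccc([N+](=O)[O-])cc1)C(=O)Nc1nnc(Cc2ccc(F)cc2)s1` has not yet been measured. It arises from compound 3 by nitro in place of methoxy on an aromatic carbon, the same change as from compound 1 to compound 2, only made on the core of compound 3 instead of the core of compound 1. The step for compound 4 in this assay is expected to be a number 3 percentage points lower from compound 3 to compound 4 (within the scatter), resting on the earlier step of a number 4 percentage points lower from compound 1 to compound 2 (within the scatter) made by the same change. Compound 4 is therefore estimated at 17%, expected between 6% and 29%.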

Compound 4, percent growth inhibition at one concentration: 8%
Compound 4: middle estimate off by 9 percentage points, on the high side, and the stated range covers the measured number.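

In this assay, nitro in place of methoxy gives a number 12 percentage points lower from compound 3 to compound 4 (beyond the scatter), and 4-fluorophenyl in place of naphthalen-1-yl gives a number 17 percentage points lower from compound 2 to compound 4 (beyond the scatter). The nitro change carries from one core to the other with no gap that stands out from the scatter: the same change on two cores in this assay, a number 4 percentage points lower (within the scatter) from compound 1 to compound 2 and a number 12 percentage points lower (beyond the scatter) from compound 3 to compound 4, 8 percentage points apart, within the scatter of two such steps The same holds for the 4-fluorophenyl change, although two steps for each change cannot show that either would carry to further cores: the same change on two cores in this assay, a number 9 percentage points lower (within the scatter) from compound 1 to compound 3 and a number 17 percentage points lower (beyond the scatter) from compound 2 to compound 4, 8 percentage points apart, within the scatter of two such steps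

The compounds shown leave open how other groups would behave at these two places, such as an amine or a carboxylic acid in place of nitro. They also leave open whether these steps would hold at other concentrations.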